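The source may hold more compounds than are shown below. What is called first, only, known or untested is meant among the compounds shown, and "the series" means these compounds.

Measured compounds:
compound 1, `COc1ccc(Cn2cnc3c(N(C)c4ccc(OC)cc4)ncnc32)cc1`, > 100000 nM
compound 2, `COc1ccc(N(C)c2ncnc3c2ncn3Cc2ccc(OC)c(OC)c2)cc1`, > 100000 nM
compound 3, `COc1ccc(N(C)c2nc(Cl)nc3c2ncn3Cc2cc(OC)cc(OC)c2)cc1`, 42000 nM

Compound 1 is measured in a functional assay on K562 cells (Homo sapiens) for antiproliferative activity, read by MTT assay, with a stated time of 48 h; a higher number here means a weaker inhibitor of growth, a lower number a stronger inhibitor of growth. For compound 1 the result is a limit of the assay, > 100000 nM, and not a number. For compound 2 the result in this assay is likewise a limit, > 100000 nM. Compound 2 differs from compound 1 by methoxy in place of hydrogen on an aromatic carbon. The step that the two limits leave unreadable from compound 1 to compound 2 cannot be read as a size because of the limit of > 100000 nM in this assay, at which 2 of the 3 values shown sit.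

For the measured compounds named here, compound 3 gives 42000 nM in this assay, the only number among the three. How the core of compound 3 differs from the core of compound 1 is not broken down here.

Compound 4, `COc1ccc(N(C)c2nc(Cl)nc3c2ncn3Cc2cc(OC)c(OC)c(OC)c2)cc1`, is not yet measured. It differs from compound 3 by methoxy in place of hydrogen on an aromatic carbon. This is the same kind of change as that from compound 1 to compound 2, but the surroundings differ: in compound 2 the entering methoxy sits ortho to a methoxy group and meta to a large group, whereas in compound 4 it sits ortho to two methoxy groups and para to a large group.

The measured instance of this change gives no readable size, so the expectation for compound 4 rests on compound 3 alone, whose value is 42000 nM. Compound 4 is expected to stay close to that, with a step of a 1.7-fold lower number from compound 3 to compound 4 (0.23 log units; within the scatter). The estimate for compound 4 in this assay is 25000 nM, within a range from 5000 nM to 100000 nM.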

Compound 4, concentration for 50% growth inhibition: 41000 nM
Compound 4: the middle estimate sits 1.6-fold (0.21 log units) below what was measured, within the range that was stated.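

In this assay, methoxy in place of hydrogen on the aromatic carbon para to a large group and ortho to two methoxy groups gives a 1.0-fold lower number from compound 3 to compound 4 (0.01 log units; within the scatter), so compound 3 and compound 4 cannot be told apart on this core, and the change shows no effect here that can be separated from the scatter. The other instance of the same change, from compound 1 to compound 2 on a different core, cannot be read as a size, because each of those two compounds gives a limit of the assay and not a number: the limit of > 100000 nM in this assay, at which 2 of the 4 values shown sit. This leaves a single readable instance, which shows that the change can be made on the core of compound 3 without a readable shift, but it does not show that the result carries over to the core of compound 1, where the entering methoxy also takes a different place on the ring.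

The compounds shown leave open whether an amine, a hydroxyl or a carboxylic acid on that ring would give a readable step in this assay where methoxy does not. They also leave open whether a longer chain such as ethoxy in place of a methoxy group would do so on the core of compound 3.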